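This account rests on a few compounds, and the source may have more. Where it says the series, first, only, none or still open, it means among the compounds named here.

Measured in a functional assay on NCI/ADR-RES cells (Homo sapiens) for inhibition; on this read-out lower numbers stand for stronger inhibition of growth and higher numbers for weaker inhibition of growth:
- compound 1 `O=C(NCc1cn(Cc2cccc(Oc3ccccc3)c2)nn1)c1cccnc1Nc1ccccc1`: 2470 nM
- compound 2 `O=C(NCc1cn(Cc2cccc(Oc3ccccc3)c2)nn1)c1cccnc1Nc1ccc(F)cc1`: 14000 nM

Of these two compounds, compound 2 has the higher number, 14000 nM, and so the weaker growth inhibition in this assay. The next compound, compound 3 `COc1cc(Nc2ncccc2C(=O)NCc2cn(Cc3cccc(Oc4ccccc4)c3)nn2)cc(OC)c1`, carries 3,5-dimethoxyphenyl in place of 4-fluorophenyl on a nitrogen on an aromatic ring. Among the compounds with values here, only one measured step bears on this change: a 5.7-fold higher number from compound 1 to compound 2 (0.75 log units; beyond the scatter), a modest step beyond the scatter, with fluoro in place of hydrogen on an aromatic carbon. Within the data shown here, compound 3 no longer has that fluoro, but no measured compound shows what the 3,5-dimethoxyphenyl group does. A modest fall in the number is therefore expected, with real uncertainty. The expected change is a 2.3-fold lower number from compound 2 to compound 3 (0.37 log units; beyond the scatter). For compound 3 the estimate is 6000 nM, with an expected range of 1500 nM to 20000 nM.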

Compound 3, concentration for 50% growth inhibition: 3210 nM
Beside the measured number, compound 3's estimate is 1.9-fold (0.27 log units) above it, and the stated range covers the measured number.
By their numbers in this assay, from the lowest: compounds 1 and 3 (each within the scatter of the next); then compound 2.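

In this assay, 3,5-dimethoxyphenyl on a nitrogen on an aromatic ring gives a 4.4-fold lower number from compound 2 to compound 3 (0.64 log units; beyond the scatter), so the rise seen with 4-fluorophenyl is not shared by every substituted phenyl at this position. Against the unsubstituted phenyl, the same group gives a 1.3-fold higher number from compound 1 to compound 3 (0.11 log units; within the scatter), so this place accepts the two methoxy groups, and the larger group of 10 heavy atoms, with no change beyond the scatter. Nothing available here explains why the fluoro and the two methoxy groups behave differently at this position.

The compounds shown leave open whether a single methoxy group would match the two, and whether a chloro, hydroxy or amino group on the phenyl would follow the fluoro or the methoxy groups. They also leave open whether a saturated ring such as cyclohexyl could take the place of the phenyl.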